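The source may hold more compounds than are shown below. What is called first, only, known or untested is meant among the compounds shown, and "the series" means these compounds.

Within the data shown here, compound 3 `O=C(/C=C/c1ccsc1)c1cc(O)c(O)c([N+](=O)[O-])c1` gives 41400 nM in an assay on isolated protein for inhibition of Amine oxidase [flavin-containing] A (Homo sapiens), read by fluorescence (on this read-out lower numbers stand for stronger inhibition and higher numbers for weaker inhibition), the lowest of the three numbers so far. Compound 1 `O=C(/C=C/c1cccc(O)c1)c1cc(O)c(O)c([N+](=O)[O-])c1` gives 43900 nM, and the step of a 1.1-fold lower number from compound 1 to compound 3 (0.03 log units; within the scatter) shows that swapping the group on the double-bonded chain carbon bound to a double-bonded chain carbon left the read-out essentially unchanged. Compound 2 `CC(=O)N1N=C(c2cc(O)c(O)c([N+](=O)[O-])c2)CC1c1ccoc1` gives 90900 nM, a higher number that lies beyond the scatter from compound 3; compound 2 also carries a different core, so its value does not speak to the change considered here.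

Compound 4 `O=C(/C=C/c1ccoc1)c1cc(O)c(O)c([N+](=O)[O-])c1` differs from compound 3 in one place: furan-3-yl in place of thiophen-3-yl on a double-bonded chain carbon bound to a double-bonded chain carbon. Among the measured compounds shown here, the only step that bears on this exchange is the one from compound 1 to compound 3, which was within the scatter, so a change of a five-membered aromatic ring with one hetero atom for another is not expected to move the number beyond the scatter. Compound 4 is therefore expected at 42000 nM. The range for compound 4 is estimated as 21000 nM to 85000 nM. The expected step is a 1.0-fold higher number from compound 3 to compound 4 (0.01 log units; within the scatter).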

Compound 4, half-maximal inhibitory concentration: 52900 nM
Compound 4: the middle estimate sits 1.3-fold (0.10 log units) below what was measured, within the range that was stated.
By their numbers in this assay, from the lowest: compounds 3, 1, 4 and 2 (each within the scatter of the next, the first and the last beyond it).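

In this assay, furan-3-yl in place of thiophen-3-yl gives a 1.3-fold higher number from compound 3 to compound 4 (0.11 log units; within the scatter), so exchanging sulfur for oxygen in this five-membered aromatic ring does not separate the two compounds at this position. Furan-3-yl in place of 3-hydroxyphenyl gives a 1.2-fold higher number from compound 1 to compound 4 (0.08 log units; within the scatter), so, on the shared core, all three ring groups at this place now lie within the scatter of one another. No accompanying measurement bears on this flat read-out.

Open, as far as these compounds go, is whether a group of another kind on the double-bonded chain carbon, such as an amine, a carboxylic acid or a longer chain, would move the number beyond the scatter. Also open, from the compounds shown here alone, is whether changes on the shared core itself would do so in a series with the same chain.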